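This account rests on a few compounds, and the source may have more. Where it says the series, first, only, none or still open, it means among the compounds named here.

Measured compounds in an ADME assay on Akata cells (Homo sapiens) for cytotoxicity, with a stated time of 7 days; a higher number here means that more compound is tolerated, a lower number that less compound is tolerated:

compound 1, `CCCNc1nc(N)nc2c1ncn2/C=C1/CC1(CO)CO` — in this assay compound 1 gives > 24000 nM, a limit of the assay.
compound 2, `CC(C)Sc1nc(N)nc2c1ncn2/C=C1/CC1(CO)CO` — in this assay compound 2 gives > 20000 nM, a limit of the assay.

Going by the values given here, compound 1 stands at a limit only; the one other value shown for this assay is a limit as well. Among the compounds with values here, the single measured step, a step that the two limits leave unreadable from compound 1 to compound 2, cannot be read because both of its values are limits, the limit of > 20000 nM in this assay, at which 1 of the 2 values shown sits, and (the limit of > 24000 nM in this assay, at which 1 of the 2 values shown sits).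

The compound to be measured next is compound 3, `Nc1nc(SCc2ccccc2)c2ncn(/C=C3/CC3(CO)CO)c2n1`. The change from compound 1 is benzylsulfanyl in place of propylamino on an aromatic carbon. Within the data shown here, it shares the move from an amino-type substituent to a sulfanyl substituent with the step from compound 1 to compound 2, but that step gives no readable size, so no measured step bears on the new one with a number.

The expectation is therefore no step beyond the scatter in this assay: compound 3 is estimated at 25000 nM, with a range from 10000 nM to 60000 nM. This corresponds to an expected step that the limit leaves unreadable from compound 1 to compound 3, and a limit rather than a number is considered the likely report.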

Compound 3, half-maximal cytotoxic concentration: > 20000 nM
Compound 3: only a limit was reported (the forecaster's own chance of this, stated with the estimate: 75%); the middle value lies beyond the limit too.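

In this assay compound 3 gives > 20000 nM as a limit of the assay. Going by these compounds alone, with compound 1 and compound 2 also standing at limits, no new step involving compound 3 can be read. The compounds shown leave open whether propylamino, isopropylsulfanyl and benzylsulfanyl differ at all in this assay once readable values are available.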